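The source may report more compounds than this note shows. Statements on the series, on what has been measured and on what is new or still open speak of the compounds shown alone.

Measured compounds:
compound 1 `CC(=O)Nc1ccc2ncc(-c3cnn(C)c3)cc2n1`, > 50000 nM
compound 2 `Cn1cc(-c2cnc3ccc(NCc4ccc(F)cc4)nc3c2)cn1`, 46600 nM
compound 3 `CC(=O)Nc1nccc2ncc(-c3cnn(C)c3)cc12`, > 50000 nM

Three compounds were tested in a functional assay on HeLa cells (Homo sapiens) for antiproliferative activity, read by MTT assay, with a stated time of 48 h; a lower number here means a stronger inhibitor, a higher number a weaker inhibitor. Compound 1 `CC(=O)Nc1ccc2ncc(-c3cnn(C)c3)cc2n1` reached only the limit of this assay, > 50000 nM. Compound 2 `Cn1cc(-c2cnc3ccc(NCc4ccc(F)cc4)nc3c2)cn1` gave a number in this assay, 46600 nM. Compound 3 `CC(=O)Nc1nccc2ncc(-c3cnn(C)c3)cc12` likewise stopped at the limit of this assay, > 50000 nM. Among the measured compounds shown here, the single step among measured compounds runs from compound 1 to compound 2: 4-fluorobenzyl in place of acetyl on a nitrogen on an aromatic ring, an at least 1.0-fold lower number from compound 1 to compound 2 (0.03 log units; that floor lies within the scatter), a step that starts from a limit and therefore carries little information. Compound 3 thus stands only at a limit, as the limit of > 50000 nM in this assay, at which 2 of the 3 values shown sit, shows.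

Compound 4 `Cn1cc(-c2cnc3ccnc(NC(=O)c4cccnc4)c3c2)cn1` has not yet been tested in this assay. It differs from compound 3 in one place: pyridin-3-yl in place of methyl on a carbonyl carbon. For the measured compounds named here, no measured step touches the carbonyl carbon of the amide, so the only comparison is the change at the amide nitrogen from compound 1 to compound 2, which left compound 2 close to the limit. Compound 4 is therefore expected to stay weak, with the step of an at least 1.2-fold lower number from compound 3 to compound 4 (0.09 log units; that floor lies within the scatter) estimated as small. Compound 4 is estimated at 40000 nM, within 12000 nM to 120000 nM.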

Compound 4, half-maximal inhibitory concentration: > 50000 nM
Compound 4 gave a limit, no number; the forecaster's own chance of this, stated with the estimate: 55%; at least 1.2-fold (0.09 log units) between middle value and limit.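

Compound 3 and compound 4 both stop at a limit in this assay, so no step can be read for pyridin-3-yl in place of methyl on the carbonyl carbon: the limit of > 50000 nM in this assay, at which 3 of the 4 values shown sit.

The compounds shown leave open how much any group on that carbonyl carbon matters in this assay, since neither compound gives a number.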